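The source may hold more compounds than are shown below. What is called first, only, known or untested is meant among the compounds shown, and "the series" means these compounds.

Compound 1 `COc1cc(CNC(=O)CCCCCCC(C)C)ccc1OC(=O)CCC(=O)Oc1ccc(C(N)=S)cc1` joins a vanillyl-type amide to a thiobenzamide through a succinate diester linker. In a functional assay on MCF7 cells (Homo sapiens) for antiproliferative activity, read by MTT assay, with a stated time of 48 h (a lower number here means a stronger inhibitor, a higher number a weaker inhibitor), compound 1 gives "not determined" (no result reported), so there is no single number for where it stands. Among the measured compounds shown here, the only measured member of this small set is compound 2 `COc1cc(CNC(=O)CCCCCCC(C)C)ccc1OCCCCOc1ccc(-c2cc(=S)ss2)cc1`, which carries a thione-bearing ring in place of the thiobenzamide and a butanediyl ether linker; in this assay compound 2 gives 49500 nM, a weak result. For the measured compounds named here, no pair of measured compounds differing in one place is available here, so nothing can be said of how single changes move the numbers.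

Compound 3 `COc1cc(CNC(=O)CCCC/C=C/C(C)C)ccc1OC(=O)CCC(=O)Oc1ccc(C(N)=S)cc1` differs from compound 1 only in the amide chain: 3-methylbut-1-en-1-yl in place of isopentyl on a saturated chain carbon, four bonds along the chain from a carbonyl carbon. Because compound 1 has no value, the step to compound 3 cannot be sized; with the alkyl chain otherwise unchanged, any shift in this assay is expected to be small, likely within the scatter, in no sure direction. Compound 3 is expected to give about 40000 nM, within 12000 nM to 130000 nM.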

Compound 3, half-maximal inhibitory concentration: > 50000 nM
Compound 3: only a limit was reported; the forecaster's own chance of this, stated with the estimate: 25%; at least 1.2-fold (0.09 log units) between middle value and limit.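

Compound 3 gives only a limit, not a number: the limit of > 50000 nM in this assay, at which 1 of the 3 values shown sits. Among the compounds shown here, compound 1 has no single number, and no step from compound 1 to compound 3 can be read. The compounds shown leave open whether 3-methylbut-1-en-1-yl in place of isopentyl shifts antiproliferative activity at all.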